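Trifluoromethyl on a Well-Tolerated Compound

A few compounds are considered here, and "the series" means these few. Any claim that something is new, unique, unknown or untested is made for them only; others in the source may bear on it.

In an ADME assay on cells (Hepatocyte, Mus musculus) for cytotoxicity, read by MTT assay, with a stated time of 24 h (a lower number here means that less compound is tolerated, a higher number that more compound is tolerated), compound 3 `O=S(=O)(c1ccccc1)n1c(-c2cn(-c3ccccc3)nc2-c2ccc(F)cc2)nc2ccccc21` gives 231000 nM, within the scatter of compound 1 `Cc1ccc(-c2nn(-c3ccccc3)cc2-c2nc3ccccc3n2S(=O)(=O)c2ccccc2)cc1` at 189000 nM. Compound 2 `Cc1ccc(-c2nn(-c3ccccc3)cc2-c2nc3ccccc3n2S(=O)(=O)c2ccc(Br)cc2)cc1` gives > 300000 nM, which is a limit of the assay. Compound 4 `O=S(=O)(c1ccc(C(F)(F)F)cc1)n1c(-c2cn(-c3ccccc3)nc2-c2ccc(F)cc2)nc2ccccc21` differs from compound 3 by trifluoromethyl in place of hydrogen on an aromatic carbon. Going by the values given here, two measured steps bear on this change. Bromo in place of hydrogen, the step most alike in kind, gave an at least 1.5-fold higher number from compound 1 to compound 2 (0.20 log units; that floor lies within the scatter). Fluoro in place of methyl gave a 1.2-fold higher number from compound 1 to compound 3 (0.09 log units; within the scatter). Neither shows a change beyond the scatter, so none is expected in this assay here. The expected step is a 1.2-fold higher number from compound 3 to compound 4 (0.07 log units; within the scatter). Compound 4 is estimated at 270000 nM, with an expected range from 170000 nM to 420000 nM.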

Compound 4, half-maximal cytotoxic concentration: 55300 nM
Beside the measured number, compound 4's estimate is 4.9-fold (0.69 log units) above it; the measured number lies below the stated range.
By their numbers in this assay, from the lowest: compound 4; then compounds 1 and 3 (each within the scatter of the next). At a limit, above all of these: compound 2.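

At this aromatic carbon, trifluoromethyl in place of hydrogen gives a 4.2-fold lower number from compound 3 to compound 4 (0.62 log units; beyond the scatter) in this assay. This is the first step among these compounds to pass the scatter, and it means that less compound is tolerated. With bromo in that place, compound 2 gives > 300000 nM, which is only a limit: the limit of > 300000 nM in this assay, at which 1 of the 4 values shown sits.

Still open, as far as these compounds go, is whether an amine or a carboxylic acid on this carbon would lower the number too. Also open, from the compounds shown here alone, is whether trifluoromethyl would do the same on compound 1, which carries methyl where compound 3 carries fluoro.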